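Removing the isopropyl from compound 3: expected outcome

This account rests on a few compounds, and the source may have more. Where it says the series, first, only, none or still open, it means among the compounds named here.

Going by the values given here, the three measured members share one fused core with a methyl group. Among the compounds with values here, compound 1 `CNc1nncc2c(C)ncn12` is the first. In a functional assay for inhibition, with Homo sapiens as the target (on this read-out lower numbers stand for stronger inhibition and higher numbers for weaker inhibition), compound 1 gives only a limit of the assay, > 48000 nM. Compound 2 `Cc1ncn2c(NN)nncc12` differs from compound 1 by an amino in place of methyl on a nitrogen on an aromatic ring. In this assay compound 2 likewise gives only a limit, > 48000 nM. The step that the two limits leave unreadable from compound 1 to compound 2 is therefore not readable in size or direction. Compound 3 `Cc1nc(C(C)C)n2c(S)nncc12` carries an isopropyl group on the core. In this assay compound 3 also gives only a limit, > 48000 nM. Compound 3 thus stands at the limit of > 48000 nM in this assay, at which 3 of the 3 values shown sit; no number separates it from the other two measured compounds.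

Compound 4 `Cc1ncn2c(S)nncc12` is compound 3 after the change (hydrogen in place of isopropyl on an aromatic carbon). Within the data shown here, no measured step bears on this kind of change, and the one step that exists cannot be read at all. Nothing in the measured set shows that the core reaches measurable inhibition. The step expected in this assay is a step that the limit leaves unreadable from compound 3 to compound 4, with no direction to be drawn from the data. Compound 4 is estimated at 100000 nM in this assay, within a range from 40000 nM to 300000 nM, most probably reported again as a limit.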

Compound 4, half-maximal inhibitory concentration: > 48000 nM
Compound 4: only a limit was reported; the forecaster's own chance of this, stated with the estimate: 90%; the middle value is on the limit's open side.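

Compound 4, like compound 1, compound 2 and compound 3, gives only a limit of the assay in this assay, so none of the steps from those three compounds to compound 4 can be read in size or direction. The compounds shown leave open whether any group on the shared core gives a measurable inhibition value.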